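Swapping tert-butyl for phenyl on a second core

The compounds below may be only part of what the source reports. "The series", "measured", "known", "first", "only" and "open" are said of these compounds alone.

Three compounds share a chlorinated benzylamide carrying a tetrazole, joined through an amide to a small ring that in turn bears an acylated hydroxy side chain. They were tested in a functional assay on a cell-free system (plasma, Homo sapiens), with a stated time of 3 min; on this read-out lower numbers stand for stronger inhibition and higher numbers for weaker inhibition. Compound 1 `CC(C)(C)C[C@@H](O)C(=O)N1N=CC[C@H]1C(=O)NCc1cc(Cl)ccc1-n1cnnn1` gives 590 nM. Compound 2 `O=C(NCc1cc(Cl)ccc1-n1cnnn1)[C@@H]1CC=NN1C(=O)[C@H](O)Cc1ccccc1` gives 1400 nM. Within the data shown here, the only change between them is phenyl in place of tert-butyl on a saturated chain carbon, two bonds along the chain from a carbonyl carbon and an oxygen on a saturated carbon, and it produced a 2.4-fold higher number from compound 1 to compound 2 (0.38 log units; beyond the scatter), so the phenyl-bearing compound is the weaker inhibitor of the two.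

Compound 3 `CC(C)(C)C[C@@H](O)C(=O)N1C[C@@H]2C[C@@H]2[C@H]1C(=O)NCc1cc(Cl)ccc1-n1cnnn1` gives 910 nM. Its core is a different ring from that of compound 1; the difference between the two cores is not broken down here. Compound 3 sits between the other two measured compounds, and both of its gaps, to compound 1 and to compound 2, fall within the usual scatter, so no order among them can be read from these numbers.

Compound 4 `O=C(NCc1cc(Cl)ccc1-n1cnnn1)[C@@H]1[C@H]2C[C@H]2CN1C(=O)[C@H](O)Cc1ccccc1` has not yet been measured. It differs from compound 3 by phenyl in place of tert-butyl on a saturated chain carbon, two bonds along the chain from a carbonyl carbon and an oxygen on a saturated carbon, which is the same change, at the same place, as that from compound 1 to compound 2. Because that change gave a 2.4-fold higher number from compound 1 to compound 2 (0.38 log units; beyond the scatter), compound 4 is expected to show a step of similar size and direction, a 2.4-fold higher number from compound 3 to compound 4 (0.38 log units; beyond the scatter), on the core of compound 3. In this assay compound 4 is therefore estimated at 2200 nM, with a likely range from 1000 nM to 4800 nM.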

Compound 4, half-maximal inhibitory concentration: 1200 nM
The estimate for compound 4 lay 1.8-fold (0.26 log units) above the measured number, within the range that was stated.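

In this assay, putting phenyl in place of tert-butyl on the core of compound 3 gives a 1.3-fold higher number from compound 3 to compound 4 (0.12 log units; within the scatter), so on this core alone the change has no effect that can be told apart from the ordinary spread of repeated measurements. Set beside the earlier step, the two results cannot be distinguished: the same change on two cores in this assay, a 2.4-fold higher number (0.38 log units; beyond the scatter) from compound 1 to compound 2 and a 1.3-fold higher number (0.12 log units; within the scatter) from compound 3 to compound 4, 1.8-fold (0.26 log units) apart, within the scatter of two such steps. The data are therefore compatible with the change behaving alike on both cores, but they do not prove that it does: one step stands clear of the scatter and the other does not, and a single pair of cores cannot establish a rule for the whole series, nor can it give the true size of the step or say why the step occurs.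

The compounds shown hold only tert-butyl or phenyl on this saturated chain carbon, so it remains open whether a cyclohexyl group, a pyridine ring or a longer chain there would give a similar step on both cores. From the compounds shown here alone, all of this also rests on a single read-out, and it is open whether the same comparison would hold on any other measure.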